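A few compounds are considered here, and "the series" means these few. Any claim that something is new, unique, unknown or untested is made for them only; others in the source may bear on it.

Measured compounds:
compound 1 `CCCCCCCCn1cc(/C=C/C(=O)c2ccc(NC(=O)CN3CCN(c4ccccc4)CC3)cc2)nn1` — in a functional assay on HeLa cells (Homo sapiens) for inhibition, read by MTT assay (on this read-out lower numbers stand for stronger inhibition and higher numbers for weaker inhibition), compound 1 gives 33800 nM
compound 2 `CCCCCCCCn1cc(/C=C/C(=O)c2ccc(N)cc2)nn1` — in this assay compound 2 gives 26900 nM
compound 3 `O=C(CN1CCN(c2ccccc2)CC1)Nc1ccc(C(=O)/C=C/c2cn(Cc3ccc(Br)cc3)nn2)cc1` — in this assay compound 3 gives 79700 nM

Compound 1 and compound 2 lie within the scatter of each other; compound 3 lies beyond both of them. Compound 1 and compound 3 differ in one place, (4-bromophenyl in place of heptyl on a saturated chain carbon bound to an aromatic nitrogen), and that change gives a 2.4-fold higher number from compound 1 to compound 3 (0.37 log units; beyond the scatter). How the core of compound 2 differs from that of compound 1 is not broken down here.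

Compound 4 `Nc1ccc(C(=O)/C=C/c2cn(Cc3ccc(Br)cc3)nn2)cc1` remains to be measured in this assay. For the measured compounds named here, it differs from compound 2 by 4-bromophenyl in place of heptyl on a saturated chain carbon bound to an aromatic nitrogen; this is the same change, at the same place, as the one from compound 1 to compound 3. Going by the values given here, the step from compound 2 to compound 4 in this assay is therefore expected to be a 2.3-fold higher number from compound 2 to compound 4 (0.36 log units; beyond the scatter), resting on a 2.4-fold higher number from compound 1 to compound 3 (0.37 log units; beyond the scatter), with some widening for the single precedent.

Compound 4 is estimated at 62000 nM in this assay. For compound 4 the expected range runs from 30000 nM to 130000 nM.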

Compound 4, half-maximal inhibitory concentration: 16400 nM
Beside the measured number, compound 4's estimate is 3.8-fold (0.58 log units) above it, and the stated range ends above it.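

For the compounds shown here, on the core of compound 2, 4-bromophenyl in place of heptyl gives a 1.6-fold lower number from compound 2 to compound 4 (0.21 log units; within the scatter) in this assay, so on this core the change produces no step that can be told from the scatter. The change therefore does not carry over with the same size or direction from the core of compound 1 to the core of compound 2, and the two steps differ: the same change on two cores in this assay, a 2.4-fold higher number (0.37 log units; beyond the scatter) from compound 1 to compound 3 and a 1.6-fold lower number (0.21 log units; within the scatter) from compound 2 to compound 4, 3.9-fold (0.59 log units) apart, beyond the scatter of two such steps. This shows that a step read on one core of the series cannot simply be transferred to the other, but with a single pair on each core it does not show which part of the cores accounts for the gap, or which of the two steps a further core would follow.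

Going by these compounds, it remains open how an unsubstituted benzyl or a shorter chain such as butyl, on the same aromatic nitrogen, would read on these two cores. Also open, on these data alone, is whether a core with a simple acetyl amide on the free amine would follow compound 1 to compound 3 or compound 2 to compound 4.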